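This account rests on a few compounds, and the source may have more. Where it says the series, first, only, none or still open, it means among the compounds named here.

Measured so far in a functional assay on HCT-116 cells (Homo sapiens) for antiproliferative activity, read by MTT assay, with a stated time of 72 h; a higher number here means a weaker inhibitor, a lower number a stronger inhibitor:
compound 1 `COc1ccc(/C=C2/CN(C)/C(=N/c3ccc(C)cc3)S2)cc1`: 11100 nM
compound 2 `COc1ccc(/C=C2/CN(C)/C(=N/c3ccc(Cl)cc3)S2)cc1`: 9800 nM
compound 3 `COc1ccc(/C=C2\S/C(=N\c3ccccc3)N(C)C2=O)cc1`: the result is a limit of the assay, > 100000 nM

Compound 2 holds the lowest of the two numbers in this assay; the nearest is compound 1, and the step of a 1.1-fold lower number from compound 1 to compound 2 (0.05 log units; within the scatter) lies within the scatter. Compound 3 sits at the limit of > 100000 nM in this assay, at which 1 of the 3 values shown sits, and gives no number.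

Compound 4 `COc1ccc(/C=C2/CN(C)/C(=N/c3ccc(F)cc3)S2)cc1` differs from compound 2 by fluoro in place of chloro on an aromatic carbon. Among the measured compounds shown here, the only measured step that bears on this change is a 1.1-fold lower number from compound 1 to compound 2 (0.05 log units; within the scatter), a swap on an aromatic carbon that left the number essentially unchanged. Carrying that over, the expected step of a 1.0-fold higher number from compound 2 to compound 4 (0.01 log units; within the scatter) is none beyond the scatter. Compound 4 is therefore estimated at 10000 nM, with an expected range from 4000 nM to 25000 nM.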

Compound 4, half-maximal inhibitory concentration: 10000 nM
Beside the measured number, compound 4's estimate shows no gap at the digits printed; the range from low to high includes it.
By their numbers in this assay, from the lowest: compounds 2, 4 and 1 (each within the scatter of the next). At a limit, above all of these: compound 3.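

In this assay the swap of 4-chlorophenyl to 4-fluorophenyl gives a 1.0-fold higher number from compound 2 to compound 4 (0.01 log units; within the scatter) and fluoro in place of methyl gives a 1.1-fold lower number from compound 1 to compound 4 (0.05 log units; within the scatter) on the same aromatic carbon. Fluoro thus joins methyl and chloro as a third group at this position that the assay does not tell apart, where the earlier compounds offered only one such pair. Nothing at hand bears on why these three groups read alike.

Open, going by these compounds, is whether an amine, a carboxylic acid or a longer chain at this position would move the number beyond the scatter. Also open, on these data alone, is whether other carbons of this aromatic ring are equally flat.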